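Cyclohexyl amide at the carbonyl of the pyrazole series

This account rests on a few compounds, and the source may have more. Where it says the series, first, only, none or still open, it means among the compounds named here.

Two amides of the shared core have been measured in a functional assay on cells for positive allosteric modulation of metabotropic glutamate receptor 5 (Rattus norvegicus), read by calcium flux; on this read-out lower numbers stand for an effect already at smaller amounts and higher numbers for an effect only at larger amounts of compound. Compound 1 `O=C(Nc1cc(-c2ccccc2)nn1-c1ccccc1)c1cccc([N+](=O)[O-])c1` gives 39 nM. Compound 2 `O=C(Nc1cc(-c2ccccc2)nn1-c1ccccc1)c1ccc([N+](=O)[O-])cc1` gives 10.7 nM. Going by the values given here, the single step between them, a 3.6-fold lower number from compound 1 to compound 2 (0.56 log units; beyond the scatter), moves the nitro group on the phenyl ring at the carbonyl carbon. Compound 2 therefore stands at the lowest number of the two, with compound 1 a modest step higher.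

Compound 3 `O=C(Nc1cc(-c2ccccc2)nn1-c1ccccc1)C1CCCCC1` is the next case: cyclohexyl in place of 4-nitrophenyl on a carbonyl carbon. Among the compounds with values here, no measured step bears directly on this change, since both measured compounds keep an aromatic ring with a nitro group at the carbonyl carbon; the one known step only shows that the position of the nitro group on that ring matters modestly. Removing the aromatic ring and its nitro group altogether is a larger change than anything measured, so the expectation in this assay is a step toward higher numbers for compound 3, estimated as a 14-fold higher number from compound 2 to compound 3 (1.15 log units; beyond the scatter). Compound 3 is thus expected to give about 150 nM, within a range of 30 nM to 1000 nM.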

Compound 3, half-maximal effective concentration: > 10000 nM
Compound 3: only a limit was reported; the forecaster's own chance of this, stated with the estimate: 15%; at least 66-fold (1.82 log units) between middle value and limit.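

In this assay compound 3 gives > 10000 nM, which is a limit of the assay and not a number: the limit of > 10000 nM in this assay, at which 1 of the 3 values shown sits. Exchanging 4-nitrophenyl for cyclohexyl on the carbonyl carbon brings an at least 930-fold higher number from compound 2 to compound 3 (2.97 log units; beyond the scatter) and exchanging 3-nitrophenyl for cyclohexyl brings an at least 250-fold higher number from compound 1 to compound 3 (2.40 log units; beyond the scatter) and both of these steps are large, whereas moving the nitro group on the ring gave only a 3.6-fold lower number from compound 1 to compound 2 (0.56 log units; beyond the scatter) and stayed modest. This place in the series therefore answers far more strongly to losing the whole nitrophenyl group than to where the nitro group sits, and among the three amides shown, a cyclohexyl ring does not stand in for either nitrophenyl group.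

The change removes the aromatic ring and the nitro group together, so the compounds shown cannot assign the loss to either one, and an unsubstituted phenyl or a nitro-bearing cyclohexyl at the carbonyl carbon would separate the two. On these data alone, with only a limit for compound 3, the true size of both new steps also stays open, as does the response to other groups here, such as an amine or a carboxylic acid on the phenyl ring.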